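The compounds below may be only part of what the source reports. "The series", "measured", "known", "first", "only" and "open" are said of these compounds alone.

Compound 1 `Cc1cn([C@@H]2C[C@H](O)[C@@H](CNC(=O)Nc3ccc(C(C)(C)C)cc3)O2)c(=O)[nH]c1=O` carries a shared core with a urea link leading to an aromatic ring that bears a tert-butyl group. It was tested in an ADME assay on MRC5 cells (Homo sapiens) for cytotoxicity; a lower number here means that less compound is tolerated, a higher number that more compound is tolerated. In this assay compound 1 gives only the limit of the assay, > 50000 nM, so no exact number is known for it. Two companions were run alongside. Compound 2 `Cc1cn([C@@H]2C[C@H](O)[C@@H](CNC(=S)Nc3ccc(Cl)c(C(F)(F)F)c3)O2)c(=O)[nH]c1=O` also gives only a limit in this assay, > 50000 nM. Compound 3 `Cc1cn([C@@H]2C[C@H](O)[C@@H](CNC(=O)Nc3cccc(COc4ccccc4)c3)O2)c(=O)[nH]c1=O` likewise gives only a limit in this assay, > 50000 nM. All three readings therefore sit at the same ceiling, (the limit of > 50000 nM in this assay, at which 3 of the 3 values shown sit), which means compound 1 stands level with every other compound shown and no one of them can be called more or less tolerated than another.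

Compound 4 `Cc1cn([C@@H]2C[C@H](O)[C@@H](CNC(=O)Nc3ccc(OCc4cccc(Cl)c4)cc3)O2)c(=O)[nH]c1=O` has not yet been measured. It differs from compound 1 in one place: (3-chlorobenzyl)oxy in place of tert-butyl on an aromatic carbon. The new group sits on an aromatic carbon of a six-membered aromatic ring of carbon only, para to a large group. Since every measured value here is a limit, no step beyond the scatter is expected; the step of a number no higher from compound 1 to compound 4 (the limit leaves the size open) is estimated to be essentially none. For compound 4 the expected value is 50000 nM, within the range 20000 nM to 100000 nM, most likely reported again only as a limit.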

Compound 4, half-maximal cytotoxic concentration: > 50000 nM
Compound 4 ended at the assay's limit; the forecaster's own chance of this, stated with the estimate: 80%; the middle value sits exactly at the limit.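

In this assay compound 4 gives > 50000 nM as a limit and not a number. Within the data shown here, no step from compound 1 to compound 4 can be read, since both stand at the same limit: the limit of > 50000 nM in this assay, at which 4 of the 4 values shown sit. The compounds shown leave open the actual tolerated concentration of each one, and whether (3-chlorobenzyl)oxy in place of tert-butyl changes it at all.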